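Flipping One Ring Stereocentre in a Weakly Cytotoxic Lactone

The compounds below may be only part of what the source reports. "The series", "measured", "known", "first", "only" and "open" are said of these compounds alone.

Compound 1 `CC(=O)O[C@@H]1OC(=O)[C@](O)(C(C)=O)[C@@H]1C` was tested in a functional assay on MCF7 cells (Homo sapiens) for cytotoxicity, read by MTT assay (a higher number here means a weaker inhibitor, a lower number a stronger inhibitor), and gave only a limit, > 50000 nM. For the measured compounds named here, its sole measured neighbour, compound 2 `CC(=O)O[C@@H]1OC(=O)[C@](Br)(C(C)=O)[C@@H]1C`, carries a bromo in place of the hydroxy and gives 17000 nM in this assay; the step of an at least 2.9-fold lower number from compound 1 to compound 2 (0.46 log units; beyond the scatter) is the only change recorded. Compound 3 `CC(=O)O[C@@H]1OC(=O)[C@@](O)(C(C)=O)[C@@H]1C` keeps every atom and bond of compound 1 and differs only in configuration: the two compounds have the same atoms and bonds and differ only in configuration as drawn: 1 of 3 stereo elements differ; a stereocentre at a saturated ring carbon is drawn R in compound 1 and S in compound 3. No measured step touches a stereocentre, so nothing shown points to a direction. Compound 3 is therefore expected to show no step beyond the scatter, a step that the limit leaves unreadable from compound 1 to compound 3, at an estimated 70000 nM (from 30000 nM to 200000 nM), most likely again a limit.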

Compound 3, half-maximal inhibitory concentration: > 50000 nM
Compound 3 was reported as a limit (the forecaster's own chance of this, stated with the estimate: 75%); the middle value does not contradict the limit.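

For the compounds shown here, compound 1 and compound 3 both stand only as limits, and no step between them can be read. Going by these compounds, whether the configuration at that saturated ring carbon changes the cytotoxicity at all remains open.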